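The source may hold more compounds than are shown below. What is called first, only, known or untested is meant among the compounds shown, and "the series" means these compounds.

Compound 1 `Cc1ccccc1Oc1ccc(N2C[C@@H](C(F)(F)F)C[C@H]2CC(=O)O)cc1` is the starting point. In an assay on HEK293 cells for binding affinity to Free fatty acid receptor 1 (Homo sapiens), read by scintillation counting and radioligand binding, with a stated time of 1 h (a higher number here means a weaker inhibitor, a lower number a stronger inhibitor), compound 1 gives 35 nM. Two close relatives have also been measured. Compound 2 `Cc1ccccc1Oc1ccc(N2CCC[C@H]2CC(=O)O)cc1` gives 4400 nM in this assay, and compound 3 `Cc1cc(OCc2ccccc2)ccc1Oc1ccc(N2C[C@@H](C(F)(F)F)C[C@H]2CC(=O)O)cc1` gives 10 nM. Among these three numbers compound 1 stands second highest: its nearest neighbour is compound 3, and compound 2 lies furthest away. The two steps leading out of compound 1 differ greatly in size. Replacing the trifluoromethyl on the saturated ring with hydrogen gives a 130-fold higher number from compound 1 to compound 2 (2.10 log units; beyond the scatter), a large change, whereas putting benzyloxy onto an aromatic carbon gives a 3.5-fold lower number from compound 1 to compound 3 (0.54 log units; beyond the scatter), a modest one.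

The next step leads to compound 4 `Cc1cccc(Oc2ccc(N3C[C@@H](C(F)(F)F)C[C@H]3CC(=O)O)cc2)c1C`. The change is methyl in place of hydrogen on an aromatic carbon. Among the measured compounds shown here, no measured step makes exactly this change. The step to compound 2 alters the saturated ring, not the aromatic one, so it says little here. The step to compound 3 is the closer guide: an addition on an aromatic carbon, with a modest effect. A methyl is a far smaller addition than benzyloxy, so compound 4 is expected to sit close to compound 1 in this assay, with at most a small step, a 1.4-fold lower number from compound 1 to compound 4 (0.15 log units; within the scatter). The estimate for compound 4 is 25 nM, within a range from 8 nM to 80 nM.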

Compound 4, inhibition constant: 60 nM
Compound 4: the middle estimate sits 2.4-fold (0.38 log units) below what was measured, and the stated range covers the measured number.
By their numbers in this assay, from the lowest: compound 3; then compounds 1 and 4 (each within the scatter of the next); then compound 2.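

Among the compounds shown here, compound 4 gives the first direct reading of this aromatic carbon, ortho to a methyl group. For the compounds shown here, none of the earlier compounds carries a substituent there. Turning the 2-methylphenoxy group into 2,3-dimethylphenoxy gives a 1.7-fold higher number from compound 1 to compound 4 (0.23 log units; within the scatter) in this assay and so leaves the result within the usual variation between repeat measurements. A single added methyl at this position therefore produces no change that can be told apart from that variation, although the data shown offer no measured explanation for this result.

The compounds shown leave open whether this carbon would accept other groups equally well, such as a chlorine atom, a methoxy group, an amine or a longer chain like ethyl, since one methyl says little about substituents of a different size or kind. Going by these compounds alone, it also remains open whether the same methyl would give a similar result on compound 3, which carries a benzyloxy group, as only the pair of compound 1 and compound 4 tests this change.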